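From compound 3 to compound 4: an aryl exchange

The compounds below may be only part of what the source reports. "The series", "measured", "known", "first", "only" and "open" are said of these compounds alone.

Measured in a functional assay on MDA-MB-436 cells (Homo sapiens) for antiproliferative activity, read by MTT assay, with a stated time of 48 h; on this read-out lower numbers stand for stronger inhibition and higher numbers for weaker inhibition:
- compound 1 `CN1CCN(c2ccc(-c3cc4c(N5CCN(S(=O)(=O)/C=C/c6ccccc6)CC5)ncnc4s3)cc2)CC1`: 8670 nM
- compound 2 `CCS(=O)(=O)N1CCN(c2ncnc3sc(-c4ccc(N5CCN(C)CC5)cc4)cc23)CC1`: 10600 nM
- compound 3 `CN1CCN(c2ccc(-c3cc4c(N5CCN(C(=O)Nc6ccc(Cl)cc6)CC5)ncnc4s3)cc2)CC1`: 9270 nM

Compound 3 stands within the scatter of both other compounds. The next compound, compound 4 `CC(C)c1cccc(C(C)C)c1NC(=O)N1CCN(c2ncnc3sc(-c4ccc(N5CCN(C)CC5)cc4)cc23)CC1`, is not yet measured. It carries 2,6-diisopropylphenyl in place of 4-chlorophenyl on an amide-type nitrogen. For the measured compounds named here, the nearest evidence is indirect, as no measured step changes this group alone. The steps are a 1.1-fold higher number from compound 1 to compound 3 (0.03 log units; within the scatter), a 1.1-fold lower number from compound 2 to compound 3 (0.06 log units; within the scatter) and a 1.2-fold higher number from compound 1 to compound 2 (0.09 log units; within the scatter), all within the scatter. In this assay, no step beyond the scatter is therefore expected, and the estimated step is a 1.0-fold lower number from compound 3 to compound 4 (0.01 log units; within the scatter). Compound 4 is expected at 9000 nM, with an estimated range of 4000 nM to 19000 nM.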

Compound 4, half-maximal inhibitory concentration: 11300 nM
Beside the measured number, compound 4's estimate is 1.3-fold (0.10 log units) below it; low and high end bracket the measured number.
By their numbers in this assay, from the lowest: compounds 1, 3, 2 and 4 (each within the scatter of the next).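

In this assay, for the compounds shown here, 2,6-diisopropylphenyl in place of 4-chlorophenyl on the amide-type nitrogen gives a 1.2-fold higher number from compound 3 to compound 4 (0.09 log units; within the scatter), the first measured step that changes this aryl group alone. At this position, an aryl group of 12 heavy atoms without chlorine and one of 7 heavy atoms with chlorine therefore stay within the scatter of each other. No supporting data bear on this result. From the compounds shown here alone, whether a carboxylic acid or a primary amine on this aryl group would give a step beyond the scatter remains open. The four compounds also leave open whether any change at this position can move the number beyond the scatter.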